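Swapping Isopropoxy for 2,2,2-Trifluoroethoxy

The compounds below may be only part of what the source reports. "The series", "measured", "known", "first", "only" and "open" are said of these compounds alone.

- compound 1 `CCOc1cc(-c2ccc3[nH]ccc3c2)cn2c(-c3cc(OC)c(OC)c(OC)c3)nnc12`: 589 nM
- compound 2 `COc1cc(-c2nnc3c(OC(C)C)cc(-c4ccc5[nH]ccc5c4)cn23)cc(OC)c1OC`: 1250 nM

Among the compounds with values here, only two compounds have been measured in a functional assay on A549 cells (Homo sapiens) for antiproliferative activity, read by MTT assay, with a stated time of 48 h (on this read-out higher numbers stand for weaker inhibition and lower numbers for stronger inhibition), and compound 2 has the higher number of the pair, at 1250 nM. Compound 3 `COc1cc(-c2nnc3c(OCC(F)(F)F)cc(-c4ccc5[nH]ccc5c4)cn23)cc(OC)c1OC` has not been measured yet. It differs from compound 2 by 2,2,2-trifluoroethyl in place of isopropyl on an oxygen on an aromatic ring, which is 2,2,2-trifluoroethyl in place of isopropyl on an oxygen on an aromatic ring. Within the data shown here, one measured step bears on this change, a 2.1-fold higher number from compound 1 to compound 2 (0.33 log units; beyond the scatter). It is modest. The structural change in that step is a methyl in place of hydrogen on the chain held by that same oxygen. No trifluoroethyl group has been measured, so this single step is a loose guide. Compound 3 gives up the isopropyl of compound 2, so a small move toward lower numbers seems likely. The expected change is a 1.6-fold lower number from compound 2 to compound 3 (0.19 log units; within the scatter). For compound 3 the estimated value is 800 nM, with an expected range of 280 nM to 2300 nM.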

Compound 3, half-maximal inhibitory concentration: 585 nM
The estimate for compound 3 lay 1.4-fold (0.14 log units) above the measured number; the range from low to high includes it.
By their numbers in this assay, from the lowest: compounds 3 and 1 (each within the scatter of the next); then compound 2.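

In this assay, 2,2,2-trifluoroethyl in place of isopropyl on an oxygen on an aromatic ring gives a 2.1-fold lower number from compound 2 to compound 3 (0.33 log units; beyond the scatter), so the step that isopropyl brought in from compound 1 is not a one-way feature of this position. Trifluoromethyl in place of methyl on the saturated chain carbon bound to that oxygen gives a 1.0-fold lower number from compound 1 to compound 3 (0.00 log units; within the scatter), so compound 1 and compound 3 cannot be told apart on this read-out, and of the three chains on the oxygen only the isopropyl of compound 2 stands apart. Nothing available here gives a reason for this pattern.

The compounds shown leave open how a longer chain such as n-butyl, or a chain ending in an amine such as 2-(dimethylamino)ethyl, would read at this oxygen. They also leave open how a free hydroxyl in place of the whole alkoxy group would compare.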